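A few compounds are considered here, and "the series" means these few. Any claim that something is new, unique, unknown or untested is made for them only; others in the source may bear on it.

Going by the values given here, in a functional assay on MCF7 cells (Homo sapiens) for inhibition, read by MTT assay (a higher number here means a weaker inhibitor of growth, a lower number a stronger inhibitor of growth), compound 1 `CC1=C(/C=C/C(C)=C/C=C/C(C)=C\C(=O)Nc2ccccc2)C(C)(C)CCC1n1ccnc1` gives 1900 nM and compound 2 `CC1=C(/C=C/C(C)=C/C=C/C(C)=C\C(=O)Nc2ccccc2O)C(C)(C)CCC1n1ccnc1` gives 1090 nM, so compound 2 stands within the scatter of the only other number. Compound 3 `CC1=C(/C=C/C(C)=C/C=C/C(C)=C\C(=O)NCc2ccc(F)cc2)C(C)(C)CCC1n1ccnc1` differs from compound 2 by 4-fluorobenzyl in place of 2-hydroxyphenyl on an amide-type nitrogen, with 4-fluorobenzyl in place of 2-hydroxyphenyl on an amide-type nitrogen. Among the compounds with values here, the one measured step, a 1.7-fold lower number from compound 1 to compound 2 (0.24 log units; within the scatter), stays within the scatter and changes a different feature, so it bears only weakly on this change. No shift beyond the scatter is therefore expected in this assay, and the estimated step is a 1.3-fold higher number from compound 2 to compound 3 (0.11 log units; within the scatter). For compound 3 the expected value is 1400 nM, with an estimated range of 500 nM to 4000 nM.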

Compound 3, concentration for 50% growth inhibition: 1930 nM
Compound 3: the middle estimate sits 1.4-fold (0.14 log units) below what was measured; the range from low to high includes it.
By their numbers in this assay, from the lowest: compounds 2, 1 and 3 (each within the scatter of the next).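

In this assay the change from 2-hydroxyphenyl to 4-fluorobenzyl on the amide-type nitrogen gives a 1.8-fold higher number from compound 2 to compound 3 (0.25 log units; within the scatter) and the change from phenyl to 4-fluorobenzyl gives a 1.0-fold higher number from compound 1 to compound 3 (0.01 log units; within the scatter) and so the number does not separate these three groups. This position thus tolerates a benzyl group as well as the two aryl groups, and losing the hydroxy group's hydrogen-bond donor brings no shift beyond the scatter. No evidence available here accounts for this result. The compounds shown leave open whether an amine or a carboxylic acid on the aromatic ring, or a longer chain on the amide-type nitrogen, would move the number beyond the scatter.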